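Hydrogen, methyl and isopropyl in the hydroxamic acid series

This account rests on a few compounds, and the source may have more. Where it says the series, first, only, none or still open, it means among the compounds named here.

Measured in a functional assay on HepG2 cells (Homo sapiens) for antiproliferative activity, read by MTT assay, with a stated time of 48 h; on this read-out lower numbers stand for stronger inhibition and higher numbers for weaker inhibition:
- compound 1 `O=C(/C=C/c1ccc(/C=C/C(=O)c2ccccc2)o1)NO`: 12100 nM
- compound 2 `CC(C)c1ccc(C(=O)/C=C/c2ccc(/C=C/C(=O)NO)o2)cc1`: 35900 nM

Going by the values given here, of these two, compound 2 carries the higher number, and compound 1 is its only neighbour. The next compound to be measured is compound 3 `Cc1ccc(C(=O)/C=C/c2ccc(/C=C/C(=O)NO)o2)cc1`. It differs from compound 2 by one change, methyl in place of isopropyl on an aromatic carbon.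

Among the compounds with values here, only one measured step bears on this change: a 3.0-fold higher number from compound 1 to compound 2 (0.47 log units; beyond the scatter). That modest step came with isopropyl in place of hydrogen on an aromatic carbon. Within the data shown here, a single step sets no trend, and no methyl compound has been measured yet. Methyl is expected to fall between hydrogen and isopropyl, so the number in this assay should move down from that of compound 2, but by less than the whole measured step, and perhaps by no more than the scatter. The expected change is a 1.8-fold lower number from compound 2 to compound 3 (0.25 log units; within the scatter). For compound 3 the estimated value is 20000 nM, with an expected range of 9000 nM to 42000 nM.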

Compound 3, half-maximal inhibitory concentration: 16000 nM
The estimate for compound 3 lay 1.3-fold (0.10 log units) above the measured number; the range from low to high includes it.
By their numbers in this assay, from the lowest: compounds 1 and 3 (each within the scatter of the next); then compound 2.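

In this assay, the place on the six-membered aromatic ring, para to a large group, now has three substituents to compare, and the numbers do not follow the heavy-atom count evenly. Methyl in place of isopropyl gives a 2.2-fold lower number from compound 2 to compound 3 (0.35 log units; beyond the scatter) and methyl in place of hydrogen gives a 1.3-fold higher number from compound 1 to compound 3 (0.12 log units; within the scatter) so hydrogen and methyl cannot be told apart in this read-out, while isopropyl in compound 2 stands apart from both with the higher number. The earlier step from hydrogen to isopropyl therefore does not reflect a change shared by any carbon substituent at this place, and nothing at hand accounts for the difference between methyl and isopropyl.

On these data alone, it remains open whether a larger branched group such as tert-butyl would carry the number further up, or whether a group of another kind, such as an amine, a methoxy group or a carboxylic acid, would leave it with hydrogen and methyl. As far as these compounds go, it is also open whether the same order would hold at other places on this ring, since all three compounds carry their change at the same place.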